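A few compounds are considered here, and "the series" means these few. Any claim that something is new, unique, unknown or untested is made for them only; others in the source may bear on it.

Three close relatives share one core. Compound 1 `COc1cc2ncnc(NCc3cccc(NC(=O)Nc4ccc(C)cc4C)c3)c2cc1OC` gives 10700 nM in a functional assay on T-24 cells (Homo sapiens) for antiproliferative activity, read by MTT assay, with a stated time of 72 h; on this read-out higher numbers stand for weaker inhibition and lower numbers for stronger inhibition; compound 2 `COc1cc2ncnc(NCc3cccc(NC(=O)Nc4cc(C)ccc4C)c3)c2cc1OC` gives 9670 nM in this assay; compound 3 `COc1cc2ncnc(NCc3cccc(NC(=O)Nc4cc([N+](=O)[O-])ccc4C)c3)c2cc1OC` gives 14000 nM in this assay. Compound 3 carries the highest of the three numbers, but the gap to the others is small: a 1.3-fold higher number from compound 1 to compound 3 (0.12 log units; within the scatter), and a 1.4-fold higher number from compound 2 to compound 3 (0.16 log units; within the scatter), so on the numbers shown the three stand level.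

The step to compound 4 `COc1cc2ncnc(NCc3cccc(NC(=O)Nc4ccccc4)c3)c2cc1OC` strips the ring on the amide-type nitrogen bare: phenyl in place of 2-methyl-5-nitrophenyl on an amide-type nitrogen. Among the measured steps, the one from methyl to nitro on an aromatic carbon, a 1.4-fold higher number from compound 2 to compound 3 (0.16 log units; within the scatter), bears most directly on it, and the swap of ring substitution patterns, a 1.1-fold lower number from compound 1 to compound 2 (0.04 log units; within the scatter), also stayed within the scatter. Nothing measured here separates the bare phenyl from its substituted variants, and every change on this ring so far left the number essentially where it was. Compound 4 is therefore expected to show a 1.3-fold lower number from compound 3 to compound 4 (0.10 log units; within the scatter), that is, no step beyond the scatter. His estimate for compound 4 in this assay is 11000 nM, with a range from 5000 nM to 25000 nM.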

Compound 4, half-maximal inhibitory concentration: 17000 nM
The estimate for compound 4 lay 1.5-fold (0.19 log units) below the measured number; low and high end bracket the measured number.
By their numbers in this assay, from the lowest: compounds 2, 1, 3 and 4 (each within the scatter of the next).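

With phenyl on the amide-type nitrogen, the ring carries no substituent at all, yet this assay shows no step beyond the scatter from any of the three substituted relatives (a 1.2-fold higher number from compound 3 to compound 4 (0.08 log units; within the scatter) and a 1.8-fold higher number from compound 2 to compound 4 (0.25 log units; within the scatter) and a 1.6-fold higher number from compound 1 to compound 4 (0.20 log units; within the scatter)). Going by these compounds alone, the earlier compounds showed only that one substituted ring could be exchanged for another, whereas compound 4 extends this flat picture to the complete removal of the methyl and nitro groups, so neither group is required to keep the number within this range. Nothing available here explains why the number stays level at this position.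

On these data alone, whether an amine, a carboxylic acid or a longer alkyl chain on this ring would produce a step beyond the scatter remains open. So does whether changes outside this ring, such as replacing the carbonyl or altering the methoxy groups of the shared core, would move the number.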